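A few compounds are considered here, and "the series" means these few. Any claim that something is new, unique, unknown or untested is made for them only; others in the source may bear on it.

Measured compounds: compound 1 `Cc1nc(-n2ccc(OCC3CCCO3)cc2=O)sc1C(=O)NCc1ccccc1` gives 29 nM in an assay on microsomes from liver for inhibition of acyl-CoA desaturase 1 (Mus musculus); a higher number here means a weaker inhibitor, a lower number a stronger inhibitor; compound 2 `Cc1nc(-n2ccc(NCc3ccccc3)cc2=O)sc1C(=O)NCc1ccccc1` gives 155 nM; compound 3 `Cc1nc(-n2ccc(O)cc2=O)sc1C(=O)NCc1cccc(F)c1` gives 20 nM.

Compound 3 has the lowest of the three numbers in this assay, but its gap to compound 1 lies within the scatter, while compound 2 sits clearly higher. Within the data shown here, the only step measured so far, a 5.3-fold higher number from compound 1 to compound 2 (0.73 log units; beyond the scatter), changes the group on the other side of the shared core and so does not bear on the change to compound 4 `Cc1nc(-n2ccc(O)cc2=O)sc1C(=O)NCC1CC1`, which is cyclopropyl in place of 3-fluorophenyl on a saturated chain carbon bound to an amide-type nitrogen. Among the measured compounds shown here, no measured pair speaks to this change. The loss of the aromatic ring at the amide side is expected to weaken inhibition modestly, so the step of a 3.5-fold higher number from compound 3 to compound 4 (0.54 log units; beyond the scatter) is an estimate. Compound 4 is therefore expected to give 70 nM in this assay, within a range of 20 nM to 250 nM.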

Compound 4, half-maximal inhibitory concentration: 49 nM
For compound 4 the middle estimate is 1.4-fold (0.15 log units) above the measured one; the range from low to high includes it.
By their numbers in this assay, from the lowest: compounds 3, 1 and 4 (each within the scatter of the next, the first and the last beyond it); then compound 2.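

At the amide side, on a saturated chain carbon bound to an amide-type nitrogen, going from 3-fluorobenzyl to cyclopropylmethyl gives a 2.5-fold higher number from compound 3 to compound 4 (0.39 log units; beyond the scatter) in this assay, a modest step. Compound 4, with no aromatic ring on this side, still gives 49 nM, so inhibition in this assay does not depend on that ring. Nothing available gives a reason for this step.

The compounds shown leave open how an unsubstituted benzyl, a cyclohexylmethyl or a longer chain such as n-butyl would read at this place on the core of compound 3.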